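This account rests on a few compounds, and the source may have more. Where it says the series, first, only, none or still open, it means among the compounds named here.

Measured compounds:
compound 1, `O=C(O)CCc1ccc(NCc2ccc(-c3ccccc3)cc2)cc1` — in a functional assay for agonist activity at Free fatty acid receptor 1 (Homo sapiens) (on this read-out higher numbers stand for an effect only at larger amounts of compound and lower numbers for an effect already at smaller amounts), compound 1 gives 251 nM
compound 2, `O=C(O)CCc1ccc(NCc2ccc(C(=O)O)cc2)cc1` — in this assay compound 2 gives only the limit < 31700 nM

Compound 2 stands at a limit of this assay rather than at a number, so its position against compound 1 cannot be read. The step from compound 1 to compound 2, a step that the limit leaves unreadable from compound 1 to compound 2, is therefore unreadable, as the limit of < 31700 nM in this assay, at which 1 of the 2 values shown sits, shows. Compound 3, `O=C(O)CCc1ccc(NCc2ccc(O)cc2)cc1`, differs from compound 2 by hydroxy in place of carboxy on an aromatic carbon. For the measured compounds named here, no measured step with a readable size bears on this change; the only step that shares the site is the one from compound 1 to compound 2, and it gives no size. The expectation for compound 3 in this assay thus rests on the value of compound 1 alone, as a weaker relative with a small polar tail, and the estimated step that the limit leaves unreadable from compound 2 to compound 3 cannot be given a direction from the data. Compound 3 is expected to give about 5000 nM, within 1000 nM to 30000 nM.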

Compound 3, half-maximal effective concentration: < 31700 nM
Compound 3: only a limit was reported; the forecaster's own chance of this, stated with the estimate: 30%; the middle value is on the limit's open side.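

In this assay, for the compounds shown here, compound 3 gives only a limit, < 31700 nM, so no step joining compound 3 to compound 1 or compound 2 can be read: the limit of < 31700 nM in this assay, at which 2 of the 3 values shown sit. The compounds shown leave open how far compound 2 and compound 3 stand from compound 1 and from each other.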